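Polyhydroxy esters: the step from compound 2 to compound 3

A few compounds are considered here, and "the series" means these few. Any claim that something is new, unique, unknown or untested is made for them only; others in the source may bear on it.

Compound 1 `CC[C@H](C)[C@@H](O)C(=O)O[C@@H](C(=O)O[C@@H](C(=O)O[C@@H](C(=O)O[C@@H](C(=O)O[C@H](CO)[C@@H](O)[C@H](O)[C@H](O)CO)[C@@H](C)CC)[C@@H](C)CC)[C@@H](C)CC)[C@@H](C)CC`: > 53200 nM (a limit)
Compound 2 `CC[C@H](C)[C@@H](O)C(=O)O[C@@H](C(=O)O[C@@H](C(=O)O[C@@H](C(=O)O[C@@H](C(=O)OC[C@@H](O)[C@@H](O)[C@H](O)[C@H](O)CO)[C@@H](C)CC)[C@@H](C)CC)[C@@H](C)CC)[C@@H](C)CC`: > 53200 nM (a limit)

In a functional assay on MIA PaCa-2 cells (Homo sapiens) for cytotoxicity, read by MTT assay, with a stated time of 24 h (a lower number here means a stronger inhibitor, a higher number a weaker inhibitor), compound 2 gives > 53200 nM, which is a limit and not a number. Among the measured compounds shown here, its standing among the measured compounds is given by the limit of > 53200 nM in this assay, at which 2 of the 2 values shown sit, so no measured compound has a numerical value yet.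

Compound 3 `CC[C@H](C)[C@@H](O)C(=O)O[C@@H](C(=O)O[C@@H](C(=O)O[C@@H](C(=O)O[C@@H](C(=O)O[C@H](CO)[C@@H](O)[C@H](O)CO)[C@@H](C)CC)[C@@H](C)CC)[C@@H](C)CC)[C@@H](C)CC` is the next to be read. The structural change is 2,3,4-trihydroxy-1-(hydroxymethyl)butyl in place of 2,3,4,5,6-pentahydroxyhexyl on an oxygen next to a carbonyl group.

For the measured compounds named here, the one measured step that bears on this change, made on the same oxygen, is a step that the two limits leave unreadable from compound 1 to compound 2. It offers no size and no direction to carry over. With nothing measured to suggest a gain, no shift beyond the scatter is expected in this assay. The expected size of the move is a step that the limit leaves unreadable from compound 2 to compound 3, and the most likely report is again a limit. For compound 3 the estimated value is 60000 nM, with an expected range of 40000 nM to 150000 nM.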

Compound 3, half-maximal inhibitory concentration: 36400 nM
Beside the measured number, compound 3's estimate is 1.6-fold (0.22 log units) above it, and the stated range ends above it.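

With 2,3,4-trihydroxy-1-(hydroxymethyl)butyl on an oxygen next to a carbonyl group, the series gains its first numerical reading in this assay: compound 3 gives 36400 nM. The change of polyhydroxy group reads as an at least 1.4-fold lower number from compound 2 to compound 3 (0.16 log units; that floor lies within the scatter), and hydrogen in place of hydroxymethyl on the saturated chain carbon reads as an at least 1.4-fold lower number from compound 1 to compound 3 (0.16 log units; that floor lies within the scatter), so each step has only a floor, and neither floor clears the scatter. The polyhydroxy group can therefore be altered at this position with a value now readable, but no real gain is established, as compound 1 and compound 2 remain limits and not numbers: the limit of > 53200 nM in this assay, at which 2 of the 3 values shown sit.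

Going by these compounds, the true distance between compound 3 and the two limited esters remains open, so the size of the effect of removing hydroxymethyl or shortening the chain is not settled. Also open, on these data alone, is how the same oxygen would read with a shorter 2,3-dihydroxypropyl group, or with a chain ending in an amine or a carboxylic acid.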